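Swapping Thiophen-2-yl for Thiophen-3-yl on a Saturated Carbon

The source may report more compounds than this note shows. Statements on the series, on what has been measured and on what is new or still open speak of the compounds shown alone.

Compound 2 `CC1=C(C(=O)OC2CCC2)C(c2cccs2)NC(=O)N1` has the higher of the two figures measured so far, though compound 1 `CC1=C(C(N)=O)C(c2ccsc2)NC(=O)N1` sits within the scatter of it. In an assay on membranes from HeLa cells for displacement of a labelled ligand from adenosine receptor A3 (Homo sapiens), read by scintillation counting, with a stated time of 180 min, tested at 1 uM (a higher number here means more inhibition at the concentration tested (going by the name of the read-out), a lower number less inhibition), compound 2 gives 2%, and compound 1 gives 1%. Compound 3 `CC1=C(C(=O)OC2CCC2)C(c2ccsc2)NC(=O)N1` keeps the atoms of compound 2 but joins them differently: thiophen-3-yl in place of thiophen-2-yl on a saturated ring carbon. Among the measured compounds shown here, no step between two measured compounds guides this change. Because compound 2 gives only 2% near the bottom of the scale, compound 3 is expected to show a number 1 percentage points higher from compound 2 to compound 3 (within the scatter), nothing beyond the scatter. The estimate for compound 3 is 3%, between -5% and 15%.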

Compound 3, a percentage reported as inhibition, at one concentration (the size of the read-out at that concentration, not a potency): 3%
Compound 3: the middle estimate sits on the measured number at the digits printed; measured number inside the range.
By their numbers in this assay, from the lowest: compounds 1, 2 and 3 (each within the scatter of the next).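

In this assay the step of a number 1 percentage points higher from compound 2 to compound 3 (within the scatter) shows that changing thiophen-2-yl to thiophen-3-yl on this saturated ring carbon does not lift the reading beyond the scatter. Likewise, a number 2 percentage points higher from compound 1 to compound 3 (within the scatter) comes with cyclobutyloxy in place of amino on the carbonyl carbon, so this second change does not separate the compounds either. No measurement at hand gives a reason for these small numbers. On these data alone, whether phenyl on the saturated ring carbon, or a longer chain such as hexyloxy on the carbonyl carbon, would give a clearly larger number stays open.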